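Exchanging the Trifluorobenzyl Group on the Ring Nitrogen

The source may hold more compounds than are shown below. What is called first, only, known or untested is meant among the compounds shown, and "the series" means these compounds.

Compound 2 `COc1ccc2[nH]c3c(c2c1)CCNC31CCN(Cc2ccc(F)c(F)c2F)CC1` has been measured in an assay on FRT cells for positive allosteric modulation of Cystic fibrosis transmembrane conductance regulator variant N1303K (Homo sapiens), in the presence of a further agent that is not named here (a higher number here means that more compound is needed for the effect, a lower number that less compound is needed), and gives 4100 nM, one of two numbers that lie within the scatter of each other. Its nearest neighbour, compound 1 `COc1ccc2[nH]c3c(c2c1)CCNC31CCN(Cc2ccc(F)c(Cl)c2F)CC1`, gives 4500 nM in this assay, and the step of a 1.1-fold lower number from compound 1 to compound 2 (0.04 log units; within the scatter) is within the scatter. Compound 3 `COc1ccc2[nH]c3c(c2c1)CCNC31CCN(C(C)c2ccccc2)CC1` is not yet measured; it differs from compound 2 on the amine nitrogen in the ring: 1-phenylethyl in place of 2,3,4-trifluorobenzyl on an amine nitrogen in a ring. Within the data shown here, no measured step bears directly on this exchange. Among the measured compounds shown here, the only known step concerns a single halogen on the aromatic ring and is within the scatter, so it offers no direction for a change that swaps the whole group and introduces a branched link. On that basis the expected step is a 1.2-fold higher number from compound 2 to compound 3 (0.09 log units; within the scatter), with wide uncertainty. The estimate for compound 3 in this assay is 5000 nM, between 1500 nM and 16000 nM.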

Compound 3, half-maximal effective concentration: 20000 nM
Compound 3: the middle estimate sits 4.0-fold (0.60 log units) below what was measured; the measured number lies above the stated range.
By their numbers in this assay, from the lowest: compounds 2 and 1 (each within the scatter of the next); then compound 3.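

In this assay the amine nitrogen in the ring proves to be a place where the number responds: 1-phenylethyl in place of 2,3,4-trifluorobenzyl gives a 4.9-fold higher number from compound 2 to compound 3 (0.69 log units; beyond the scatter) and 1-phenylethyl in place of 3-chloro-2,4-difluorobenzyl gives a 4.4-fold higher number from compound 1 to compound 3 (0.65 log units; beyond the scatter) as its counterpart. Exchanging the whole group on this nitrogen therefore moves the number beyond the scatter, which the exchange of one halogen on the aromatic ring had not done. Nothing available here accounts for the rise.

The exchange removes all the halogens from the aromatic ring and adds a branch to the link in one step, so the compounds shown cannot say which of the two changes carries the rise. Unsubstituted benzyl or 1-(2,3,4-trifluorophenyl)ethyl on this nitrogen would each hold one of those changes apart from the other.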